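The compounds below may be only part of what the source reports. "The series", "measured", "known", "first", "only" and "open" are said of these compounds alone.

Of the compounds shown here, three have been tested in an ADME assay on MT4 cells (Homo sapiens) for cytotoxicity, read by MTT assay (a higher number here means that more compound is tolerated, a lower number that less compound is tolerated), so far. Compound 1, `[O-]c1on[n+](-c2ccc(Cc3ccc(-[n+]4noc([O-])c4CN4CCN(c5ccccc5)CC4)cc3)cc2)c1CN1CCN(c2ccccc2)CC1`, a dimeric structure in which two cores are joined through a methylene bridge, gives 10.3 ug/mL. Compound 2, `Cc1ccc(-[n+]2noc([O-])c2CN2CCN(c3cccc(Cl)c3)CC2)cc1`, a single core bearing a methyl-substituted phenyl ring and a piperazine capped with a 3-chlorophenyl group, gives 27.5 ug/mL. Compound 3, `CN1CCN(Cc2c([O-])on[n+]2-c2ccc(Cc3ccc(-[n+]4noc([O-])c4CN4CCN(C)C(c5ccccc5)C4)cc3)cc2)CC1c1ccccc1`, another dimer, gives 14 ug/mL.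

Among these three numbers compound 2 stands highest. Compound 3 sits nearest, and the gap between compound 2 and compound 3 lies within the scatter of repeated measurements, so no order between them can be claimed. Compound 1 sits furthest, and that gap lies beyond the scatter.

The new compound 4, `Cc1ccc(-[n+]2noc([O-])c2CN2CCN(C)CC2)cc1`, keeps the core and the methyl-substituted phenyl ring of compound 2 and differs in one place: methyl in place of 3-chlorophenyl on an amine nitrogen in a ring.

For the measured compounds named here, no pair of measured compounds differs in exactly this way, so the data give no direct precedent for this change. Compound 3, whose piperazine nitrogen also carries a methyl, sits within the scatter of compound 2 in this assay, which is the only hint available. Compound 4 is therefore expected to show a step from compound 2 that is a 1.0-fold higher number from compound 2 to compound 4 (0.01 log units; within the scatter), not clearly beyond the scatter in either direction. The estimate for compound 4 in this assay is 28 ug/mL, with a range from 12 ug/mL to 65 ug/mL.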

Compound 4, half-maximal cytotoxic concentration: 12.7 ug/mL
The estimate for compound 4 lay 2.2-fold (0.34 log units) above the measured number, and the stated range covers the measured number.
By their numbers in this assay, from the lowest: compounds 1, 4, 3 and 2 (each within the scatter of the next, the first and the last beyond it).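

In this assay, the swap of 3-chlorophenyl for methyl on the amine nitrogen in the ring gives a 2.2-fold lower number from compound 2 to compound 4 (0.34 log units; beyond the scatter), a modest step that lies beyond the scatter. For the compounds shown here, this is the only comparison so far in which a single place changes, so it is the first direct sign that the group on this nitrogen can alone move the number, with less compound tolerated when methyl stands there. The earlier compounds could not show this, as they differ from one another in more than one place, and nothing measured here accounts for the step.

The compounds shown do not tell whether the step follows the chlorine, the aromatic ring or simply the loss of heavy atoms at this nitrogen, and a benzyl group or a butyl chain in the same place would help to separate these readings. Going by these compounds, whether the same swap gives a step of similar size on the dimeric structures, or with another group in place of the methyl on the phenyl ring of the core, also stays open.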